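The compounds below may be only part of what the source reports. "The series", "measured", "known", "first", "only" and "open" are said of these compounds alone.

Measured in an ADME assay on the whole organism (Mus musculus, strain Swiss Webster) for pharmacokinetics, read by LC-MS, at a dose of 50 mg/kg by the oral route; on this read-out lower numbers stand for lower exposure and higher numbers for higher exposure at the dose given:
- compound 1 `O=C(Nc1ccc(F)c(-c2nc3ncc(-c4ccc(F)cc4F)cc3[nH]2)c1)N1CCCC1`: 9500 nM
- compound 2 `O=C(Nc1ccc(F)c(-c2nc3ncc(-c4cncc(F)c4)cc3[nH]2)c1)N1CCCC1`: 1070 nM

Compound 1 stands highest of these two numbers. Compound 3 `O=C(Nc1ccc(F)c(-c2nc3ncc(-c4cccc(F)c4F)cc3[nH]2)c1)N1CCCC1` has the same atoms as compound 1, joined differently: 2,3-difluorophenyl in place of 2,4-difluorophenyl on an aromatic carbon. It carries 2,3-difluorophenyl in place of 2,4-difluorophenyl on an aromatic carbon. Going by the values given here, the only measured step, an 8.9-fold lower number from compound 1 to compound 2 (0.95 log units; beyond the scatter), brought in 5-fluoropyridin-3-yl, a different kind of ring, so it offers only a loose guide. Here the ring remains one of carbon only, so no step beyond the scatter is expected in this assay, and the expected step is a 1.5-fold lower number from compound 1 to compound 3 (0.16 log units; within the scatter). For compound 3 the estimated value is 6500 nM, with an expected range of 2500 nM to 15000 nM.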

Compound 3, maximal plasma concentration: 1830 nM
Compound 3: the middle estimate sits 3.6-fold (0.55 log units) above what was measured; measured number outside the range, below it.
By their numbers in this assay, from the lowest: compounds 2 and 3 (each within the scatter of the next); then compound 1.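

Moving one fluorine, with the same atoms kept, changes the result in this assay beyond the scatter (a 5.2-fold lower number from compound 1 to compound 3 (0.72 log units; beyond the scatter)). At this position, then, the arrangement of the fluorines on a carbon-only ring matters, not only the swap to a ring containing nitrogen. The 2,3-difluorophenyl and 5-fluoropyridin-3-yl groups stay within the scatter of each other (a 1.7-fold higher number from compound 2 to compound 3 (0.23 log units; within the scatter)), and no evidence here accounts for the difference in exposure.

On these data alone, it remains open whether 2,4-difluorophenyl is unusual here, or whether 4-fluorophenyl or a ring carrying a morpholine would match compound 1.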